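Swapping the Phenyl Substituent in a Cytotoxicity Series

The source may hold more compounds than are shown below. What is called first, only, known or untested is meant among the compounds shown, and "the series" means these compounds.

Of the compounds shown here, two sharing one core have been tested in a functional assay on NCI-H460 cells (Homo sapiens) for cytotoxicity, read by MTT assay, with a stated time of 72 h; a higher number here means a weaker inhibitor, a lower number a stronger inhibitor. Compound 1 `COc1ccc(-c2ccnc(C(=O)Nc3ccc(Oc4ccnc5cc(OCCCN6CCCCC6)c(OC)cc45)c(F)c3)c2)cc1` gives 200 nM, and compound 2 `COc1cc2c(Oc3ccc(NC(=O)c4cc(-c5ccccc5C)ccn4)cc3F)ccnc2cc1OCCCN1CCN(C)CC1` gives 150 nM in this assay. Compound 2 has the lower of the two numbers, but the gap to compound 1 lies within the usual scatter, so the two cannot be told apart. Compound 3 `COc1cc2c(Oc3ccc(NC(=O)c4cc(-c5ccc(C(F)(F)F)cc5)ccn4)cc3F)ccnc2cc1OCCCN1CCN(C)CC1` is not yet measured; it differs from compound 2 in one place: 4-(trifluoromethyl)phenyl in place of 2-methylphenyl on an aromatic carbon. Among the compounds with values here, no measured pair in this set shows what such a change does, so nothing here points to a step beyond the scatter in either direction. Compound 3 is therefore expected to land close to compound 2, with an estimated step of a 1.3-fold higher number from compound 2 to compound 3 (0.12 log units; within the scatter) in this assay. The estimate for compound 3 is 200 nM, within a range from 70 nM to 600 nM.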

Compound 3, half-maximal inhibitory concentration: 160 nM
Compound 3: middle estimate off by 1.3-fold (0.10 log units), on the high side; the range from low to high includes it.
By their numbers in this assay, from the lowest: compounds 2, 3 and 1 (each within the scatter of the next).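

Within the data shown here, this is the first measured step at this place on the ring, the aromatic carbon opposite the ring nitrogen. In this assay, replacing 2-methylphenyl with 4-(trifluoromethyl)phenyl gives a 1.1-fold higher number from compound 2 to compound 3 (0.03 log units; within the scatter), so the two compounds cannot be told apart even though the entering group is larger and differs in both its substituent and where that substituent sits on the phenyl ring. Because both features change in this single swap, the step cannot assign a contribution to either one, and no evidence on why the values match is available here.

The compounds shown leave open whether a smaller or very different group at this place, such as a plain phenyl, a carboxylic acid or an amine, would move the value beyond the scatter. They also leave open what 2-(trifluoromethyl)phenyl or 4-methylphenyl would do, which would separate the two features.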